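The compounds below may be only part of what the source reports. "The series", "measured", "known", "first", "only" and "open" are said of these compounds alone.

In a functional assay on HEK293 cells for negative allosteric modulation of metabotropic glutamate receptor 5 (Homo sapiens), read by FLIPR and calcium flux (on this read-out higher numbers stand for weaker inhibition and lower numbers for stronger inhibition), compound 1 `CN1CCc2nc(C#Cc3ccc(Cl)cc3)ccc2C1=O` gives 352 nM. Within the data shown here, compound 2 `CC(C)N1CCc2nc(C#Cc3ccccc3Cl)ccc2C1=O` in this assay gives 2520 nM, the higher of the two numbers so far, with compound 1 as its nearest point at a lower number, a gap beyond the scatter. Compound 3 `CC(C)N1CCc2nc(C#Cc3cccs3)ccc2C1=O` carries thiophen-2-yl in place of 2-chlorophenyl on a triple-bonded carbon. Among the measured compounds shown here, no measured pair shows this change, so its size is open. Compound 1 at 352 nM shows that a different ring at this place can go with a lower number. The step from compound 2 to compound 3 is expected at about a 3.2-fold lower number from compound 2 to compound 3 (0.50 log units; beyond the scatter), a lowering of modest size. Compound 3 is expected to give 800 nM, within 250 nM to 2500 nM.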

Compound 3, half-maximal inhibitory concentration: 45 nM
The estimate for compound 3 lay 18-fold (1.25 log units) above the measured number; measured number below the stated range.
By their numbers in this assay, from the lowest: compound 3; then compound 1; then compound 2.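

At this place, on a triple-bonded carbon, the ring is a strong determinant of the number: in this assay, thiophen-2-yl in place of 2-chlorophenyl gives a 56-fold lower number from compound 2 to compound 3 (1.75 log units; beyond the scatter). A five-membered aromatic ring with a sulfur atom is therefore well accepted here on this core. Nothing available accounts for the size of this step.

Open, going by these compounds, is whether unsubstituted phenyl, furan-2-yl or a pyridine ring at this place gives a number like that of compound 3, which would separate the loss of chlorine from the change of ring. Also open, on these data alone, is whether the step holds on the methyl-bearing core of compound 1.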